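The compounds below may be only part of what the source reports. "The series", "measured", "known", "first", "only" and "open" are said of these compounds alone.

Measured compounds:

Compound 1 `NS(=O)(=O)c1ccc(N2N=C(c3ccccc3)CC2c2ccccc2F)cc1` in an ADME assay on Vero 76 cells (Chlorocebus sabaeus) for cytotoxicity, read by MTT assay, with a stated time of 96 h (on this read-out higher numbers stand for lower toxicity in this test and lower numbers for higher toxicity in this test), gives 28000 nM.
Compound 2 `NS(=O)(=O)c1ccc(N2N=C(c3ccc(OCc4ccccc4)cc3)CC2c2ccccc2)cc1` gives > 100000 nM, which is a limit of this assay rather than a number.
Compound 3 `NS(=O)(=O)c1ccc(N2N=C(c3ccc(Oc4ccccc4)cc3)CC2c2ccccc2)cc1` gives 85000 nM.

From the compounds shown here alone, compound 2 therefore stands at the top of the measured range, at the limit of > 100000 nM in this assay, at which 1 of the 3 values shown sits, so its true value is unknown beyond that floor. Among the measured compounds shown here, the one step among the measured compounds, an at least 1.1-fold lower number from compound 2 to compound 3 (0.07 log units; that floor lies within the scatter), concerns the group on the oxygen and not the ring that changes here.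

Compound 4 `Cc1cccc(C2CC(c3ccc(OCc4ccccc4)cc3)=NN2c2ccc(S(N)(=O)=O)cc2)c1` differs from compound 2 as follows: methyl in place of hydrogen on an aromatic carbon. For the measured compounds named here, no measured step touches that ring or a methyl, so no step bears directly on this change, and the only step known is small and within the scatter. The expectation is therefore of a step no larger than the scatter, with compound 4 likely again reaching the limit of this assay, and the estimated step is a number no higher from compound 2 to compound 4 (the limit leaves the size open). Compound 4 is estimated at 100000 nM, in a range from 50000 nM to 200000 nM.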

Compound 4, half-maximal cytotoxic concentration: 100000 nM
Beside the measured number, compound 4's estimate shows no gap at the digits printed; the range from low to high includes it.
By their numbers in this assay, from the lowest: compound 1; then compounds 3 and 4 (each within the scatter of the next).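

In this assay, set against the phenyl of compound 2, the 3-methylphenyl of compound 4 gives 100000 nM, so a methyl at this place on the ring still leaves a high number, which on this read-out means low toxicity in the test. Compound 2 gives > 100000 nM, which is a limit of this assay and not a number. The step is a number no higher from compound 2 to compound 4 (the limit leaves the size open) and its size cannot be read: the limit of > 100000 nM in this assay, at which 1 of the 4 values shown sits.

From the compounds shown here alone, whether an ethyl, a methoxy, an amine or a carboxylic acid at this place on the ring would keep the number this high stays open. So does whether the same methyl would act alike in compound 3, with its phenyl on the oxygen.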